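A few compounds are considered here, and "the series" means these few. Any claim that something is new, unique, unknown or untested is made for them only; others in the source may bear on it.

Measured compounds:
compound 1, `CCOC(=O)CN(C)C(=O)c1ccc(C(CC)(CC)c2ccc(OCCC(O)(CC)CC)c(C)c2)n1CC`: 520 nM
compound 2, `CCOC(=O)C(CC(=O)OC)NC(=O)c1ccc(C(CC)(CC)c2ccc(OCCC(O)(CC)CC)c(C)c2)n1CC`: 21 nM

Within the data shown here, in an assay on cells for agonist activity at vitamin D3 receptor (Homo sapiens), with a stated time of 96 h (on this read-out higher numbers stand for an effect only at larger amounts of compound and lower numbers for an effect already at smaller amounts), compound 2 gives the lowest of the two numbers, and the single measured step, a 25-fold lower number from compound 1 to compound 2 (1.39 log units; beyond the scatter), shows the change on the carbonyl carbon of the amide to be large. Among the measured compounds shown here, no other step bears on compound 2.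

Compound 3, `CCC(C)C(NC(=O)c1ccc(C(CC)(CC)c2ccc(OCCC(O)(CC)CC)c(C)c2)n1CC)C(=O)O`, is the next structure. It differs from compound 2 thus: a group of 8 heavy atoms (6 carbon, 2 oxygen; no ring) in place of a group of 11 heavy atoms (7 carbon, 4 oxygen; no ring), on an amide-type nitrogen. The group that leaves carries the two ester functions of compound 2; the group that enters is 1-carboxy-2-methylbutyl, and the amide nitrogen keeps its hydrogen. For the measured compounds named here, the one measured step speaks only to the importance of what sits at this end of the molecule; nothing measured exchanges an ester for a carboxy group, so the direction is open. The expectation is that compound 3 stays near compound 2, with a small step of a 1.7-fold higher number from compound 2 to compound 3 (0.22 log units; within the scatter), since the large gain came with the move away from the methylated nitrogen, which compound 3 retains. Compound 3 is estimated at 35 nM, within a range of 8 nM to 150 nM.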

Compound 3, half-maximal effective concentration: 860 nM
For compound 3 the middle estimate is 25-fold (1.39 log units) below the measured one; measured number above the stated range.
By their numbers in this assay, from the lowest: compound 2; then compounds 1 and 3 (each within the scatter of the next).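

In this assay the step of a 41-fold higher number from compound 2 to compound 3 (1.61 log units; beyond the scatter) shows that the amide hydrogen alone does not secure the low number of compound 2: with that hydrogen kept, the group on the amide-type nitrogen still decides the outcome. The step of a 1.7-fold higher number from compound 1 to compound 3 (0.22 log units; within the scatter) stays within the scatter, so the read-out does not separate (1-carboxy-2-methylbutyl)amino from ((ethoxycarbonyl)methyl)(methyl)amino on the carbonyl carbon, and the large gain seen with compound 2 cannot be assigned to loss of the methyl on nitrogen alone. No measurement at hand accounts for the loss on going to the carboxy-bearing group.

The change from compound 2 to compound 3 replaces the two ester functions and alters the carbon chain at once, leaving open whether the carboxy group or the 2-methylbutyl chain carries the step. A 1-(methoxycarbonyl)-2-methylbutyl group on the same nitrogen would divide these two changes, and a diacid counterpart of the group in compound 2 would test the ester functions on an unchanged carbon skeleton.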